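Lengthening the alkyl chain: from compound 3 to compound 4

A few compounds are considered here, and "the series" means these few. Any claim that something is new, unique, unknown or untested is made for them only; others in the source may bear on it.

Measured compounds:
compound 1 `CCCCCCCCSC[C@H](NC(C)=O)C(=O)CCl` gives 5600 nM in a functional assay on NALM-6 cells (Homo sapiens); on this read-out higher numbers stand for weaker inhibition and lower numbers for stronger inhibition
compound 2 `CCCCCCCCCSC[C@H](NC(C)=O)C(=O)CCl` gives 7300 nM in this assay
compound 3 `CCCCCCCCCCCCSC[C@H](NC(C)=O)C(=O)CCl` gives 2000 nM in this assay

Compound 3 gives the lowest number of the three in this assay, and its separation from both others is beyond the scatter. Compound 4 `CCCCCCCCCCCCCCCSC[C@H](NC(C)=O)C(=O)CCl` differs from compound 3 in one place: propyl in place of hydrogen on a saturated chain carbon, ten or more bonds along the chain from a sulfur. The same kind of change has been seen twice among the measured compounds. Going from the shortest chain, a 2.8-fold lower number from compound 1 to compound 3 (0.45 log units; beyond the scatter), and from the next, a 3.7-fold lower number from compound 2 to compound 3 (0.56 log units; beyond the scatter). Both point the same way, toward lower numbers with a longer chain. The one smaller extension, a 1.3-fold higher number from compound 1 to compound 2 (0.12 log units; within the scatter), did not. On that basis a modest further drop is expected for compound 4, with the step estimated as a 1.7-fold lower number from compound 3 to compound 4 (0.22 log units; within the scatter), though it may also come out flat. The estimate for compound 4 in this assay is 1200 nM, with a range from 400 nM to 4000 nM.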

Compound 4, half-maximal inhibitory concentration: 8900 nM
The estimate for compound 4 lay 7.4-fold (0.87 log units) below the measured number; the whole stated range lies below it.
By their numbers in this assay, from the lowest: compound 3; then compounds 1, 2 and 4 (each within the scatter of the next).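

In this assay, lengthening the chain at this position does not keep lowering the number, since the propyl extension reverses the earlier direction (a 4.5-fold higher number from compound 3 to compound 4 (0.65 log units; beyond the scatter)). The long chain of compound 4 also cannot be told apart from the two shorter chains (a 1.2-fold higher number from compound 2 to compound 4 (0.09 log units; within the scatter); a 1.6-fold higher number from compound 1 to compound 4 (0.20 log units; within the scatter)), so compound 3 alone stands apart among these four and chain length gives no steady trend: the chains of compound 1, compound 2 and compound 4 lie within the scatter of one another despite their different lengths. Nothing available here explains why the number rises again at compound 4.

Still open, on these data alone, is how the numbers behave for chains of intermediate length between those of compound 3 and compound 4, and for a longer chain. Also open, as far as these compounds go, is what a chain ending in an amine or a carboxylic acid would give at the same position.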